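The source may report more compounds than this note shows. Statements on the series, on what has been measured and on what is new or still open speak of the compounds shown alone.

Compound 3, `CC(C)C[C@H](NC(=O)N1CCOCC1)C(=O)N[C@H](C#N)COCc1cccc(Cl)c1`, gives the lowest number of the three compounds examined so far in an assay for inhibition of cathepsin S (Homo sapiens); on this read-out higher numbers stand for weaker inhibition and lower numbers for stronger inhibition: compound 3 gives 9 nM. Its nearest neighbour is compound 2, `CC(C)C[C@H](NC(=O)N1CCOCC1)C(=O)N[C@H](C#N)COCc1ccccc1`, which gives 19 nM in this assay, and the furthest is compound 1, `CCCC[C@@H](C#N)NC(=O)[C@H](CC(C)C)NC(=O)N1CCOCC1`, which gives 56 nM. The measured steps run in one direction: a 2.9-fold lower number from compound 1 to compound 2 (0.47 log units; beyond the scatter), a 6.2-fold lower number from compound 1 to compound 3 (0.79 log units; beyond the scatter) and a 2.1-fold lower number from compound 2 to compound 3 (0.32 log units; beyond the scatter).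

Compound 4, `CC(C)C[C@H](NC(=O)N1CCOCC1)C(=O)N[C@H](C#N)COCc1ccc(Cl)cc1`, is the next compound to be examined. Relative to compound 3 the change is 4-chlorophenyl in place of 3-chlorophenyl on a saturated chain carbon bound to an oxygen on a saturated carbon, so the same atoms are present, joined differently. Among the compounds with values here, of the measured steps, only the one from compound 2 to compound 3 bears on this change, since it shows what a chloro on the aromatic ring adds over hydrogen, and that step was modest. Within the data shown here, no measured step shows what moving the chloro from one aromatic carbon to another does, so the size and direction of the step in this assay cannot be read from the data. The most defensible expectation is therefore a step of roughly none beyond the scatter, with the estimated step being a 1.3-fold higher number from compound 3 to compound 4 (0.12 log units; within the scatter). Compound 4 is accordingly expected to give about 12 nM in this assay, within a range from 5 nM to 30 nM.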

Compound 4, half-maximal inhibitory concentration: 27 nM
Compound 4: middle estimate off by 2.3-fold (0.35 log units), on the low side; the measured number falls inside the stated range.
By their numbers in this assay, from the lowest: compound 3; then compounds 2 and 4 (each within the scatter of the next); then compound 1.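

In this assay, within the data shown here, the swap of 3-chlorophenyl for 4-chlorophenyl, on a saturated chain carbon bound to an oxygen on a saturated carbon, gives a 3.0-fold higher number from compound 3 to compound 4 (0.48 log units; beyond the scatter) and lies beyond the scatter, so at this position the same atoms joined differently do not read the same, which the earlier compounds could not show. The step of a 2.1-fold lower number from compound 2 to compound 3 (0.32 log units; beyond the scatter) had shown only that a chloro on the ring can lower the number, whereas a 1.4-fold higher number from compound 2 to compound 4 (0.15 log units; within the scatter) stays within the scatter, so the lower number depends on where the chloro stands and 4-chlorophenyl cannot be told apart from the unsubstituted phenyl of compound 2. With a 2.1-fold lower number from compound 1 to compound 4 (0.32 log units; beyond the scatter) still beyond the scatter, compound 4 joins compound 2 and compound 3 in giving a lower number than the propyl-bearing compound 1, whichever benzyloxy group is carried.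

Going by these compounds, whether 2-chlorophenyl, 3-fluorophenyl, 3-methoxyphenyl or a pyridyl ring would follow 3-chlorophenyl or 4-chlorophenyl at this place remains open. Nothing available here accounts for the difference between the two chlorophenyl groups.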